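Swapping the Aromatic Substituent Before the Next Hindlimb Test

This account rests on a few compounds, and the source may have more. Where it says the series, first, only, none or still open, it means among the compounds named here.

Of the compounds shown here, three sharing one core have been tested in a functional assay on the whole organism (Hindlimb) for inhibition, with Mus musculus as the target, with a stated time of 0.5 h; a higher number here means that more compound is needed for the effect, a lower number that less compound is needed. Compound 1 `Cc1ccc(C(=O)NN2C(=O)NC3(CC3(C)C)C2=O)cc1` gives 100 mg/kg, compound 2 `Cc1cccc(C(=O)NN2C(=O)NC3(CC3(C)C)C2=O)c1` gives 100 mg/kg, and compound 3 `CC(C)(C)c1ccc(C(=O)NN2C(=O)NC3(CC3(C)C)C2=O)cc1` gives 30 mg/kg. Moving the methyl from one aromatic position to another, as in no change at the digits printed from compound 1 to compound 2 (within the scatter), made no difference beyond the scatter. Replacing methyl with a larger tert-butyl, as in a 3.3-fold lower number from compound 1 to compound 3 (0.52 log units; beyond the scatter), brought a modest improvement, so that compound 3 holds the lowest number of the three, with its steps to both compound 1 and compound 2 beyond the scatter.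

Compound 4 `CC1(C)CC12NC(=O)N(NC(=O)c1ccc(Cl)cc1)C2=O` is the next candidate. It differs from compound 3 by chloro in place of tert-butyl on an aromatic carbon. Going by the values given here, no measured step compares chloro with anything else, so the only guide is that the one change to a larger group, from compound 1 to compound 3, gave a lower number, and the chloro group is small. The expectation is therefore that compound 4 loses part or all of that gain, with a step of a 3.3-fold higher number from compound 3 to compound 4 (0.52 log units; beyond the scatter) in this assay. Compound 4 is estimated to need 100 mg/kg, within a range from 30 mg/kg to 300 mg/kg, in this assay.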

Compound 4, minimum effective dose: 100 mg/kg
Compound 4: middle estimate and measured number agree at the digits printed; the measured number falls inside the stated range.
By their numbers in this assay, from the lowest: compound 3; then compounds 1, 2 and 4 (each within the scatter of the next).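

In this assay, chloro on this aromatic carbon does not hold the gain seen with tert-butyl, and a group of four heavy atoms giving way to one of a single heavy atom brings a 3.3-fold higher number from compound 3 to compound 4 (0.52 log units; beyond the scatter). Chloro and methyl at this carbon cannot be told apart, with no change at the digits printed from compound 1 to compound 4 (within the scatter), and the 4-chlorophenyl group also reads the same as the 3-methylphenyl group, with no change at the digits printed from compound 2 to compound 4 (within the scatter). Among the groups shown on this ring, tert-butyl is thus the only one that stands apart, and nothing available here bears on the reason for this.

Going by these compounds, with only tert-butyl set against methyl and chloro, it remains open whether the lower number follows the count of heavy atoms in the group or is particular to tert-butyl itself, and an isopropyl group, a cyclohexyl ring or a trifluoromethyl group on the same carbon would help to separate these two readings. Also open, on these data alone, is how this carbon would respond to a group able to form hydrogen bonds, such as an amine or a carboxylic acid, since both groups that leave and enter here count no donors or acceptors.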